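This account rests on a few compounds, and the source may have more. Where it says the series, first, only, none or still open, it means among the compounds named here.

In an assay on Cerebral cortex for displacement of a labelled ligand from Adrenergic receptor alpha-1 (Rattus norvegicus) (a lower number here means a stronger inhibitor, a higher number a weaker inhibitor), compound 1 `COc1ccccc1N1CCN(CCCCn2nc(-c3ccc(C)cc3)c3ccccc3c2=O)CC1` gives 2.6 nM. Compound 2 `Cc1ccc(-c2nn(CCCCN3CCN(c4cccc(Cl)c4)CC3)c(=O)c3ccccc23)cc1` carries a 3-chlorophenyl in place of the 2-methoxyphenyl on an amine nitrogen in a ring, and in this assay compound 2 gives 12.4 nM. The step is a 4.8-fold higher number from compound 1 to compound 2 (0.68 log units; beyond the scatter). Going by the values given here, compound 2 thus has the higher of the two numbers known so far, with compound 1 as its only neighbour.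

Compound 3 `Cc1ccc(-c2nn(CCCCN3CCN(c4ncccn4)CC3)c(=O)c3ccccc23)cc1` differs from compound 2 in the same position: pyrimidin-2-yl in place of 3-chlorophenyl on an amine nitrogen in a ring. Among the compounds with values here, the one step that bears on this change is the exchange of the group on that same ring nitrogen, a 4.8-fold higher number from compound 1 to compound 2 (0.68 log units; beyond the scatter), which was of modest size. Within the data shown here, with only one such step to go by, and no measured compound carrying a pyrimidin-2-yl, the expectation for compound 3 is a further rise in the number, estimated as a 3.2-fold higher number from compound 2 to compound 3 (0.51 log units; beyond the scatter). In this assay compound 3 is expected to give about 40 nM, within a range of 10 nM to 160 nM.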

Compound 3, inhibition constant: 270 nM
Beside the measured number, compound 3's estimate is 6.8-fold (0.83 log units) below it; the whole stated range lies below it.
By their numbers in this assay, from the lowest: compound 1; then compound 2; then compound 3.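

In this assay the group on an amine nitrogen in a ring proves to matter far more than the exchange of one substituted phenyl for another suggested: a 22-fold higher number from compound 2 to compound 3 (1.34 log units; beyond the scatter) is a large step, whereas a 4.8-fold higher number from compound 1 to compound 2 (0.68 log units; beyond the scatter) was only modest. Over the three compounds the span reaches a 100-fold higher number from compound 1 to compound 3 (2.02 log units; beyond the scatter) with only this one group changed, and compound 3, the only one here with hetero atoms in the aromatic ring on that nitrogen, has the highest number, beyond the scatter from both others. Nothing available here accounts for the size of this rise.

Pyrimidin-2-yl differs from both phenyl groups in its ring atoms and in carrying no substituent, so the compounds shown cannot separate these two changes; an unsubstituted phenyl or a pyridin-2-yl on the same nitrogen would bear on that. Going by these compounds, it also remains open whether a change of this size would persist with a shorter chain in place of the present one, or with another group in place of the 4-methylphenyl on the core.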